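A few compounds are considered here, and "the series" means these few. Any claim that something is new, unique, unknown or untested is made for them only; others in the source may bear on it.

Compound 1 `COc1ccc(/C(=N/O)c2cccc3ccccc23)c(OC)c1OC` is the anchor of this small set. Within the data shown here, in a functional assay on HCT-116 cells (Homo sapiens) for inhibition, read by sulforhodamine B assay, with a stated time of 48 h (on this read-out higher numbers stand for weaker inhibition and lower numbers for stronger inhibition), compound 1 gives 5880 nM, the only number among the three values shown. Compound 2 `COc1cc(COC(c2ccc(OC)c(OC)c2OC)c2cccc3ccccc23)cc(OC)c1` reaches only the limit of the assay, > 20000 nM. Compound 3 `C=C(c1ccc(OC)c(OC)c1OC)c1cccc2ccccc12` likewise stops at the limit, > 20000 nM. Compound 1 therefore stands alone with a measured value, while the other two sit at the limit of > 20000 nM in this assay, at which 2 of the 3 values shown sit.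

Compound 4 `COc1ccc(/C(=N/OC(C)=O)c2cccc3ccccc23)c(OC)c1OC` differs from compound 1 in one place: acetyl in place of hydrogen on an oxygen, the oxygen whose other neighbour is the double-bonded nitrogen; cut one bond further out, the change reads hydroxy to acetoxy. Among the measured compounds shown here, no measured pair of compounds shows a step of this kind, so there is no basis for expecting a shift in one direction. The expected step is a 1.0-fold higher number from compound 1 to compound 4 (0.01 log units; within the scatter), none beyond the scatter. Compound 4 is accordingly estimated in this assay at 6000 nM, with a range from 1500 nM to 20000 nM.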

Compound 4, half-maximal inhibitory concentration: 4980 nM
The estimate for compound 4 lay 1.2-fold (0.08 log units) above the measured number, within the range that was stated.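

Among these compounds, compound 4 gives the first reading of a change on the oxygen whose other neighbour is the double-bonded nitrogen: in this assay, hydroxy to acetoxy gives a 1.2-fold lower number from compound 1 to compound 4 (0.07 log units; within the scatter). The hydrogen on that oxygen can therefore be replaced by acetyl with no shift beyond the scatter, and this holds for this one pair only. Compound 4 also gives a number and not a limit, so the limit remains confined to the other two compounds: the limit of > 20000 nM in this assay, at which 2 of the 4 values shown sit.

What the compounds shown leave open is how other groups on that oxygen would read, such as a methyl, a longer acyl chain, or a chain ending in an amine or a carboxylic acid. A single step also cannot tell whether acetyl would behave the same way on another core.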